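Urea aryl swaps: three measured compounds, one pending

This account rests on a few compounds, and the source may have more. Where it says the series, first, only, none or still open, it means among the compounds named here.

Three measured compounds share one core and differ only in the aryl group on the urea nitrogen. Compound 1 `CCc1nc2ccccc2c(=O)n1NC(=O)Nc1ccc(OC)cc1` carries 4-methoxyphenyl, compound 2 `CCc1nc2ccccc2c(=O)n1NC(=O)Nc1ccc(I)cc1` 4-iodophenyl and compound 3 `CCc1nc2ccccc2c(=O)n1NC(=O)Nc1cccc(C)c1` 3-methylphenyl. In a functional assay on the whole organism (strain albino) with Mus musculus as the target, at a dose of 100 mg/kg by the intraperitoneal route (a higher number here means more inhibition at the dose given (going by the name of the read-out), a lower number less inhibition), compound 1 gives 48%, compound 2 gives 55% and compound 3 gives 53%. The steps between them are small: a number 7 percentage points higher from compound 1 to compound 2 (within the scatter), a number 5 percentage points higher from compound 1 to compound 3 (within the scatter) and a number 2 percentage points lower from compound 2 to compound 3 (within the scatter). Compound 3 stands second highest of the three numbers, with compound 2 nearest and compound 1 furthest, but both gaps lie within the scatter, so no ranking among the three can be claimed.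

Compound 4 `CCc1nc2ccccc2c(=O)n1NC(=O)Nc1ccccc1C` is not yet measured. It differs from compound 3 as follows: 2-methylphenyl in place of 3-methylphenyl on an amide-type nitrogen. Among the compounds with values here, no measured step exchanges one methylphenyl for another; the closest comparisons are the aryl swaps from compound 1 to compound 3 and from compound 2 to compound 3, which stayed within the scatter, as did the swap from compound 1 to compound 2. Since every aryl change so far left this assay essentially flat, a step of a number 1 percentage points lower from compound 3 to compound 4 (within the scatter) is expected, that is, none beyond the scatter. Compound 4 is therefore estimated at 52%, with a range from 40% to 64%.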

Compound 4, a percentage reported as inhibition, in the whole organism at one dose (the size of the read-out at that dose, not a potency): 54%
The estimate for compound 4 lay 2 percentage points below the measured number; the range from low to high includes it.
By their numbers in this assay, from the lowest: compounds 1, 3, 4 and 2 (each within the scatter of the next).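

Within the data shown here, exchanging 3-methylphenyl for 2-methylphenyl on the amide-type nitrogen moves only the methyl group around the ring, and in this assay the result is a number 1 percentage points higher from compound 3 to compound 4 (within the scatter); this is the first direct comparison of two methylphenyl groups, and it shows no effect of that move beyond the scatter. The comparisons with the other two aryl groups read the same way, with a number 1 percentage points lower from compound 2 to compound 4 (within the scatter) and a number 6 percentage points higher from compound 1 to compound 4 (within the scatter), so the four aryl groups shown at this position are not separated by this read-out at the single dose given. No supporting measurement bears on why the read-out stays flat across these four compounds.

From the compounds shown here alone, whether a different kind of group on this nitrogen, such as cyclohexyl or a phenyl ring carrying a carboxylic acid or an amine, would leave the number unchanged remains open. Going by these compounds, the shared core is constant in all four compounds, so it is also open whether the same flat picture would hold with a longer chain in place of the ethyl group or at other doses.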